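The source may hold more compounds than are shown below. What is called first, only, known or untested is meant among the compounds shown, and "the series" means these compounds.

- Compound 1 `CC1=CC[C@@H]([C@@](C)(O)CCCC(C)(C)NC(=S)N/N=C\c2ccccc2)CC1`: 9960 nM
- Compound 2 `CC1=CC[C@@H]([C@@](C)(O)CCCC(C)(C)NC(=S)N/N=C\c2ccc([N+](=O)[O-])cc2)CC1`: 12300 nM
- Compound 3 `CC1=CC[C@@H]([C@@](C)(O)CCCC(C)(C)NC(=S)N/N=C\c2cccc(Cl)c2)CC1`: 6890 nM

In a functional assay on HT-29 cells (Homo sapiens) for cytotoxicity, read by sulforhodamine B assay (a lower number here means a stronger inhibitor of growth, a higher number a weaker inhibitor of growth), compound 3 gives 6890 nM, which is not clearly separated from the other two compounds: a 1.4-fold lower number from compound 1 to compound 3 (0.16 log units; within the scatter), and a 1.8-fold lower number from compound 2 to compound 3 (0.25 log units; within the scatter).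

Compound 4 `CC1=CC[C@@H]([C@@](C)(O)CCCC(C)(C)NC(=S)N/N=C\c2ccc(Cl)cc2)CC1` has the same atoms as compound 3, joined differently: 4-chlorophenyl in place of 3-chlorophenyl on a carbon with a double bond to nitrogen. The nearest evidence is the chloro step itself, a 1.4-fold lower number from compound 1 to compound 3 (0.16 log units; within the scatter). The nitro step is similarly small, a 1.2-fold higher number from compound 1 to compound 2 (0.09 log units; within the scatter). Neither change to the aromatic ring left the scatter, so no real shift is expected from this swap. The expected step is a 1.2-fold higher number from compound 3 to compound 4 (0.06 log units; within the scatter). For compound 4 the estimated value is 8000 nM, with an expected range of 4000 nM to 15000 nM.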

Compound 4, concentration for 50% growth inhibition: 7350 nM
For compound 4 the middle estimate is 1.1-fold (0.04 log units) above the measured one; the range from low to high includes it.
By their numbers in this assay, from the lowest: compounds 3, 4, 1 and 2 (each within the scatter of the next).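

In this assay, 4-chlorophenyl in place of 3-chlorophenyl gives a 1.1-fold higher number from compound 3 to compound 4 (0.03 log units; within the scatter) and so leaves the two chloro placements unseparated. Chloro in place of hydrogen gives a 1.4-fold lower number from compound 1 to compound 4 (0.13 log units; within the scatter) and chloro in place of nitro gives a 1.7-fold lower number from compound 2 to compound 4 (0.22 log units; within the scatter) at this new place, so compound 4 joins the other three compounds with no separation. Nothing available here offers an explanation for this result.

Still open, going by these compounds, is whether a methoxy group or an amine on this ring, or a second chloro, would give a value clearly apart from these four.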